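The source may hold more compounds than are shown below. What is called first, only, known or untested is meant among the compounds shown, and "the series" means these compounds.

In a functional assay on A-431 cells (Homo sapiens) (on this read-out lower numbers stand for an effect already at smaller amounts and higher numbers for an effect only at larger amounts of compound), compound 3 `COc1cc(Nc2ncccc2-c2nc(Nc3ccc(OC)cc3OC)n[nH]2)cc(OC)c1` has no number to stand on: its entry reads "not determined" (no result reported) and offers no starting point for a step. The nearest numbers come from two compounds that share its core. In this assay compound 1 `COc1cccc(Nc2n[nH]c(-c3cccnc3Nc3cc(OC)cc(OC)c3)n2)c1` gives 90 nM and compound 2 `COc1ccc(Nc2n[nH]c(-c3cccnc3Nc3cc(OC)cc(OC)c3)n2)cc1` gives 83 nM on the same scale. The change examined here leads to compound 4 `COc1cccc(CNc2n[nH]c(-c3cccnc3Nc3cc(OC)cc(OC)c3)n2)c1` and is a swap of 3-methoxybenzyl in place of 2,4-dimethoxyphenyl on a nitrogen on an aromatic ring. Counted out, the difference is 3-methoxybenzyl in place of 2,4-dimethoxyphenyl on a nitrogen on an aromatic ring and it is the only thing separating the two structures. Just one measured step bears on this place, namely a 1.1-fold lower number from compound 1 to compound 2 (0.04 log units; within the scatter) and it is small. That step exchanges one methoxyphenyl group for another, so it gives no measure of what a benzyl group does on that nitrogen. With no number at the start, neither a size nor a direction of step can be stated in this assay for this change. The expectation therefore leans on the level of the two measured compounds, with a wide margin. For compound 4 the estimate is 130 nM as the expected middle, with 35 nM to 500 nM as the expected range.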

Compound 4, half-maximal effective concentration: 120 nM
Compound 4: the middle estimate sits 1.1-fold (0.03 log units) above what was measured; low and high end bracket the measured number.
By their numbers in this assay, from the lowest: compounds 2, 1 and 4 (each within the scatter of the next).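

In this assay, among the compounds shown here, compound 4 gives the first reading of a group other than a methoxyphenyl on this nitrogen, and 3-methoxybenzyl takes that place with a 1.4-fold higher number from compound 2 to compound 4 (0.16 log units; within the scatter) and with a 1.3-fold higher number from compound 1 to compound 4 (0.12 log units; within the scatter) on the same core. Both steps stay within the scatter, so among compounds 1, 2 and 4 the swap from either methoxyphenyl group to 3-methoxybenzyl leaves no difference that can be read. On these three compounds, then, the nitrogen carries a benzyl group as well as a directly attached methoxyphenyl group, with the read-out remaining at the same level.

For the compounds shown here, compound 3 has no number, so no step to or from it can be read, and what 2,4-dimethoxyphenyl does at this place stays open. Also open, from the compounds shown here alone, is whether the flat picture holds for quite different groups on this nitrogen, such as an unsubstituted benzyl, a 2-phenylethyl chain or a chain ending in a carboxylic acid or an amine. Nothing available on these compounds accounts for the outcome.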